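The compounds below may be only part of what the source reports. "The series", "measured", "known", "first", "only" and "open" are said of these compounds alone.

In an ADME assay on MDBK cells (Bos taurus) for cytotoxicity (a higher number here means that more compound is tolerated, a lower number that less compound is tolerated), compound 1 (`Fc1cccc(F)c1Cn1ccc2nc(-c3ccccc3)nc-2c1`) gives > 100000 nM, which is a limit and not a number. Compound 2 (`CCC(CC)Cn1ccc2nc(-c3ccccc3)nc-2c1`), on the same core, gives > 100000 nM, again only a limit, so its place on the scale is not known more closely. The evidence so far is the limit of > 100000 nM in this assay, at which 2 of the 2 values shown sit. Compound 3 (`C(=C/c1ccccc1)\Cn1ccc2nc(-c3ccccc3)nc-2c1`) keeps the core and changes one group: 2-phenylethenyl in place of pentan-3-yl on a saturated chain carbon bound to an aromatic nitrogen. Among the compounds with values here, the only measured step that bears on this change is a step that the two limits leave unreadable from compound 1 to compound 2, so no size can be carried over from it. In this assay, no step beyond the scatter is therefore expected, although any readable value could only lie on the side of less compound tolerated. The expected change is an at least 1.2-fold lower number from compound 2 to compound 3 (0.09 log units; that floor lies within the scatter). Compound 3 is estimated at 80000 nM, with an expected range from 30000 nM to 100000 nM.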

Compound 3, half-maximal cytotoxic concentration: 78000 nM
For compound 3 the middle estimate is 1.0-fold (0.01 log units) above the measured one, and the stated range covers the measured number.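

In this assay, within the data shown here, compound 3 is the only one of the three compounds with a readable number, so a group on the saturated chain carbon bound to an aromatic nitrogen now has a place on the scale rather than a limit. Replacing pentan-3-yl with 2-phenylethenyl gives an at least 1.2-fold lower number from compound 2 to compound 3 (0.10 log units; that floor lies within the scatter) and replacing 2,6-difluorophenyl with 2-phenylethenyl gives an at least 1.2-fold lower number from compound 1 to compound 3 (0.10 log units; that floor lies within the scatter) so neither change is shown to exceed the scatter. The step between compound 1 and compound 2 cannot be read, and limits still dominate the picture: the limit of > 100000 nM in this assay, at which 2 of the 3 values shown sit.

Going by these compounds, the full size of both readable steps remains open, as only their floors are known. Also open, on these data alone, is whether an amine, a carboxylic acid or a longer chain at this position would give a step beyond the scatter in this assay on the shared core.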